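This account rests on a few compounds, and the source may have more. Where it says the series, first, only, none or still open, it means among the compounds named here.

Compound 3 `Cc1ccc(NC2=C(C(=O)c3ccccc3)C(c3ccc(Br)cc3)N(CCCn3ccnc3)C2=O)cc1` gives the second highest of the three numbers shown, though every step among them stays within the scatter: in a functional assay on A549 cells (Homo sapiens) for antiproliferative activity, read by MTT assay, with a stated time of 72 h (a lower number here means a stronger inhibitor, a higher number a weaker inhibitor), compound 3 gives 29400 nM. Compound 1 `CCOC1=C(C(=O)c2ccccc2)C(c2ccc(Br)cc2)N(CCCn2ccnc2)C1=O` gives 35300 nM and compound 2 `O=C(C1=C(Nc2ccccc2)C(=O)N(CCCn2ccnc2)C1c1ccc(Br)cc1)c1ccccc1` gives 24100 nM, with a 1.2-fold lower number from compound 1 to compound 3 (0.08 log units; within the scatter), a 1.5-fold lower number from compound 1 to compound 2 (0.17 log units; within the scatter) and a 1.2-fold higher number from compound 2 to compound 3 (0.09 log units; within the scatter) all small. Compound 4 `O=C(C1=C(Nc2cccc(Br)c2)C(=O)N(CCCn2ccnc2)C1c1ccc(Br)cc1)c1ccccc1` differs from compound 3 in one place: 3-bromophenyl in place of 4-methylphenyl on an amine nitrogen. Among the measured compounds shown here, the one measured step that alters the same ring, a 1.2-fold higher number from compound 2 to compound 3 (0.09 log units; within the scatter), was within the scatter, so no step beyond the scatter is expected here, and a 1.1-fold lower number from compound 3 to compound 4 (0.04 log units; within the scatter) is the expected size. Compound 4 is therefore estimated at 27000 nM, with a range from 12000 nM to 60000 nM.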

Compound 4, half-maximal inhibitory concentration: 15800 nM
The estimate for compound 4 lay 1.7-fold (0.23 log units) above the measured number, and the stated range covers the measured number.
By their numbers in this assay, from the lowest: compounds 4, 2, 3 and 1 (each within the scatter of the next, the first and the last beyond it).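

Adding bromo to the aromatic ring gives a 1.5-fold lower number from compound 2 to compound 4 (0.18 log units; within the scatter), and the exchange of 4-methylphenyl for 3-bromophenyl on the amine nitrogen gives a 1.9-fold lower number from compound 3 to compound 4 (0.27 log units; within the scatter), so both steps in this assay stay within the scatter. Only the replacement of ethoxy by (3-bromophenyl)amino, a 2.2-fold lower number from compound 1 to compound 4 (0.35 log units; beyond the scatter), passes beyond the scatter, the one step shown to do so, and it is modest. No measurement here offers an explanation for these steps. On these data alone, whether a carboxylic acid or an amine on that aromatic ring, or a longer chain on the amine nitrogen, would shift the number further remains open.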